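This account rests on a few compounds, and the source may have more. Where it says the series, first, only, none or still open, it means among the compounds named here.

Among the measured compounds shown here, compound 2, with the structure `O=S(=O)(c1ccccc1)c1nc2ccccc2nc1N1CCC(O)CC1`, is the only member of this small set to give a numerical result: in a functional assay on PC-3 cells (Homo sapiens) for cytotoxicity, read by MTT assay, with a stated time of 72 h (on this read-out lower numbers stand for stronger inhibition and higher numbers for weaker inhibition), compound 2 gives 4980 nM. Compound 1, with the structure `COc1ccc(S(=O)(=O)c2nc3ccccc3nc2N2CCc3ccccc3C2)cc1`, stands apart, since in this assay compound 1 reaches only the assay limit of > 50000 nM, a boundary rather than a number; this is described by the limit of > 50000 nM in this assay, at which 1 of the 2 values shown sits. For the measured compounds named here, compound 2 therefore stands as the sole measured value, with one further result given only as a limit.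

Compound 3, with the structure `COc1ccc(S(=O)(=O)c2nc3ccccc3nc2N2CCC(O)CC2)cc1`, has not yet been measured. It differs from compound 2 by a single change: methoxy in place of hydrogen on an aromatic carbon. Going by the values given here, no measured pair in this set shares exactly this change, so the expectation rests on the structures alone. A modest weakening in this assay is expected for compound 3, with an estimated result of 8000 nM, in a range from 2500 nM to 30000 nM. The expected step is a 1.6-fold higher number from compound 2 to compound 3 (0.21 log units; within the scatter).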

Compound 3, half-maximal inhibitory concentration: 9730 nM
For compound 3 the middle estimate is 1.2-fold (0.09 log units) below the measured one; measured number inside the range.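

With the rest of the molecule held fixed, the change from phenyl to 4-methoxyphenyl, para to a large group, gives in this assay a 2.0-fold higher number from compound 2 to compound 3 (0.29 log units; within the scatter), so these two groups cannot be told apart at this position. With 4-methoxyphenyl held fixed instead, the group on the other side of the shared core makes a clear difference: 4-hydroxypiperidin-1-yl in place of 1,2,3,4-tetrahydroisoquinolin-2-yl gives an at least 5.1-fold lower number from compound 1 to compound 3 (0.71 log units; beyond the scatter). The result for compound 1 is a limit of the assay and not a number: the limit of > 50000 nM in this assay, at which 1 of the 3 values shown sits.

On these data alone, the true size of that second step stays open, since one end of it is only a limit. Also open, as far as these compounds go, is whether a different group in place of methoxy, such as an amine, a carboxylic acid or a longer chain, would shift the result beyond the scatter.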